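Removing a methoxy group from a low-inhibition prenylated benzene

This account rests on a few compounds, and the source may have more. Where it says the series, first, only, none or still open, it means among the compounds named here.

Compound 3 `COc1c(C)c(C/C=C(\C)CC/C=C(\C)CCC=C(C)C)c(OC)c(OC)c1OC` stands lowest of the three measured compounds in an assay on cells for inhibition of Amine oxidase [flavin-containing] B (Homo sapiens), read by fluorescence, with stated times of 10 min and 20 min, tested at 25 uM; on this read-out higher numbers stand for more inhibition at the one concentration tested (going by the name of the read-out) and lower numbers for less inhibition: compound 3 gives 15.2%, while compound 2 `CC(C)=CCc1c(O)cc(O)c(C=O)c1C` gives 36.3% and compound 1 `COc1c(C)c(C/C=C(\C)CCC=C(C)C)c(OC)c(OC)c1OC` gives 38%. Going by the values given here, the one single-place step seen so far, a number 22.8 percentage points lower from compound 1 to compound 3 (beyond the scatter), lengthened the chain. Compound 4 `COc1cc(C)c(C/C=C(\C)CC/C=C(\C)CCC=C(C)C)c(OC)c1OC` differs from compound 3 elsewhere: hydrogen in place of methoxy on an aromatic carbon. Among the compounds with values here, no measured step touches a methoxy group on the aromatic ring, so there is nothing to point in either direction for this assay. Compound 4 is therefore expected to stay close to compound 3, with a step of a number 1.8 percentage points higher from compound 3 to compound 4 (within the scatter) that lies within the scatter. The estimate for compound 4 is 17%, within a range from 3% to 35%.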

Compound 4, a percentage reported as inhibition, at one concentration (the size of the read-out at that concentration, not a potency): 34.9%
Estimate against measurement, compound 4: 17.9 percentage points below, within the range that was stated.
By their numbers in this assay, from the lowest: compound 3; then compounds 4, 2 and 1 (each within the scatter of the next).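

Replacing the methoxy group with hydrogen on this aromatic carbon gives a number 19.7 percentage points higher from compound 3 to compound 4 (beyond the scatter) in this assay, so the ring substitution matters to this read-out, not only the chain. This step runs in the opposite direction to the chain-lengthening step, a number 22.8 percentage points lower from compound 1 to compound 3 (beyond the scatter). Nothing measured here explains the rise.

Going by these compounds, it remains open whether the same change would raise the number on the shorter chain of compound 1. On these data alone, how an amine or a chlorine on this aromatic carbon would compare with hydrogen and methoxy also remains open.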